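The source may report more compounds than this note shows. Statements on the series, on what has been measured and on what is new or still open speak of the compounds shown alone.

In a functional assay on HEK293 cells for agonist activity at G-protein coupled receptor 39 (Homo sapiens), read by inositol phosphate accumulation (on this read-out lower numbers stand for an effect already at smaller amounts and higher numbers for an effect only at larger amounts of compound), compound 1 `CNc1nc(NCc2ccc(Cl)cc2Cl)cc(-c2ccccn2)n1` gives 0.8 nM, the lowest of the two numbers measured, while compound 2 `CC(C)(C)CNc1nc(NCC2CC2)cc(-c2ccccn2)n1` gives 5000 nM; the gap between these two values is far beyond the usual scatter. Compound 2 differs from compound 1 in more than one place, so the two values alone do not show which change accounts for the gap. Compound 3 `CNc1nc(NCC2CCCCC2)cc(-c2ccccn2)n1` has not yet been measured in this assay. It is made from compound 1 by one change: cyclohexyl in place of 2,4-dichlorophenyl on a saturated chain carbon bound to a nitrogen on an aromatic ring. Since no single-step comparison of this kind has been measured, the expected step from compound 1 to compound 3 rests only on the two values shown, and because compound 2, which also carries a saturated ring in place of an aromatic one at this nitrogen, gives 5000 nM, a sizeable loss is expected, a 63-fold higher number from compound 1 to compound 3 (1.80 log units; beyond the scatter), though a smaller one than that seen with compound 2. For compound 3 the estimated value in this assay is 50 nM, with a range from 5 nM to 500 nM.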

Compound 3, half-maximal effective concentration: 11 nM
The estimate for compound 3 lay 4.5-fold (0.66 log units) above the measured number; low and high end bracket the measured number.
By their numbers in this assay, from the lowest: compound 1; then compound 3; then compound 2.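

In this assay, putting cyclohexyl in place of 2,4-dichlorophenyl on a saturated chain carbon bound to a nitrogen on an aromatic ring gives a 14-fold higher number from compound 1 to compound 3 (1.14 log units; beyond the scatter). Within the data shown here, this is the first comparison in which only this group differs, and it shows that an aromatic ring is not essential here: with its non-aromatic ring, compound 3 still gives 11 nM, although the step is large. No measurement at hand gives a reason for this step.

Cyclohexyl differs from 2,4-dichlorophenyl both in lacking the chlorine atoms and in its ring not being aromatic, so the compounds shown do not separate these two differences. Plain phenyl at this place could separate them, and how a longer chain or an amine there would fare remains open.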